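A few compounds are considered here, and "the series" means these few. Any claim that something is new, unique, unknown or untested is made for them only; others in the source may bear on it.

Measured compounds:
Compound 1 `O=C(NCc1nn2c(Cc3ccccc3)nnc2s1)c1ccccc1` gives 21.2% in a functional assay on the whole organism (strain Wistar) for inhibition, with Rattus norvegicus as the target, read by paw edema, with stated times of 30 min and 2 h, at a dose of 20 mg/kg by the oral route; on this read-out higher numbers stand for more inhibition at the one dose given (going by the name of the read-out) and lower numbers for less inhibition.
Compound 2 `c1ccc(OCc2nnc3sc(Cc4cccc5ccccc45)nn23)cc1` gives 18.5% in this assay.
Compound 3 `O=C(NCc1nn2c(-c3ccccc3O)nnc2s1)c1ccccc1` gives 24.4% in this assay.

On these numbers compound 2 stands lowest of the three, but its nearest neighbour is compound 1, and even compound 3, the furthest, is within the scatter of it, so the three compounds cannot be ordered. The unmeasured compound 4 `Oc1ccccc1-c1nnc2sc(Cc3cccc4ccccc34)nn12` is reached from compound 2 by one change on the shared core: 2-hydroxyphenyl in place of phenoxymethyl on an aromatic carbon. Going by the values given here, only one measured step speaks to this change, and only in part: a number 3.2 percentage points higher from compound 1 to compound 3 (within the scatter), where the same 2-hydroxyphenyl entered, though there it replaced a benzyl rather than a phenoxymethyl. That step stayed within the scatter. Among the compounds with values here, no step from a phenoxymethyl is available. Within the data shown here, on this basis the change is expected to be small and in the same upward sense as the one from compound 1 to compound 3, but not beyond the scatter. The step estimated in this assay is a number 2.5 percentage points higher from compound 2 to compound 4 (within the scatter). Compound 4 is therefore expected to give about 21%, with a range from 10% to 32%.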

Compound 4, a percentage reported as inhibition, in the whole organism at one dose (the size of the read-out at that dose, not a potency): 28%
Compound 4: middle estimate off by 7 percentage points, on the low side; low and high end bracket the measured number.
By their numbers in this assay, from the lowest: compounds 2, 1, 3 and 4 (each within the scatter of the next).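

In this assay the aromatic carbon between two ring nitrogen atoms now has a second step in which 2-hydroxyphenyl enters, here in place of phenoxymethyl, and the step reads a number 9.5 percentage points higher from compound 2 to compound 4 (within the scatter) on the shared core. Together with the step of a number 3.2 percentage points higher from compound 1 to compound 3 (within the scatter) where it replaced benzyl, this shows the same change staying within the scatter with two different groups leaving and two different groups held at the other end of the core. The change adds a hydrogen-bond donor, but nothing measured here connects that count to the result.

As far as these compounds go, it remains open whether a plain phenyl or a 2-methoxyphenyl would read differently from 2-hydroxyphenyl at this position. Also open, from the compounds shown here alone, is whether an amine or a carboxylic acid on this carbon would give a step beyond the scatter.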